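Chloro for methyl on a pyrrole-linked aryl ring

This account rests on a few compounds, and the source may have more. Where it says the series, first, only, none or still open, it means among the compounds named here.

Compound 1, `Cc1ccc(-c2ccc(C(=O)N[C@H](c3nc(C)c(CCO)s3)[C@@H]3CCCCN3)[nH]2)cc1F`, in a toxicity assay on TZM cells (Homo sapiens) for cytotoxicity, read by XTT assay, with a stated time of 3 days (a lower number here means that less compound is tolerated, a higher number that more compound is tolerated), gives 28800 nM.
Compound 2, `Cc1nc([C@@H](NC(=O)c2ccc(-c3ccc(Cl)c(F)c3)[nH]2)[C@@H]2CCCCN2)sc1CCO`, in this assay gives 16100 nM.
Compound 3, `Cc1ccc(-c2ccc(C(=O)N[C@@H](c3nc(C)c(CCCO)s3)[C@@H]3CCCCN3)[nH]2)cc1F`, in this assay gives 17000 nM.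

Compound 2 differs from compound 1 by chloro in place of methyl on an aromatic carbon. That change gave a 1.8-fold lower number from compound 1 to compound 2 (0.25 log units; within the scatter) in this assay. Compound 4, `Cc1nc([C@H](NC(=O)c2ccc(-c3ccc(Cl)c(F)c3)[nH]2)[C@@H]2CCCCN2)sc1CCCO`, is made from compound 3 by the same change, (chloro in place of methyl on an aromatic carbon), at a place described in identical words. The difference between the core of compound 1 and the core of compound 3 is not broken down here; their values lie within the scatter of each other. Within the data shown here, since the one measured instance of this change stayed within the scatter, the step from compound 3 to compound 4 is expected to be small, about a 1.4-fold lower number from compound 3 to compound 4 (0.15 log units; within the scatter) in this assay. Compound 4 is therefore estimated at 12000 nM, between 5000 nM and 30000 nM.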

Compound 4, half-maximal cytotoxic concentration: 8200 nM
Beside the measured number, compound 4's estimate is 1.5-fold (0.17 log units) above it; the range from low to high includes it.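

In this assay the swap of 3-fluoro-4-methylphenyl for 4-chloro-3-fluorophenyl gave a 2.1-fold lower number from compound 3 to compound 4 (0.32 log units; beyond the scatter) and so left less compound tolerated, a modest step. Both instances of the change point the same way and do not differ in size, so it carried from one core to the other here: the same change on two cores in this assay, a 1.8-fold lower number (0.25 log units; within the scatter) from compound 1 to compound 2 and a 2.1-fold lower number (0.32 log units; beyond the scatter) from compound 3 to compound 4, 1.2-fold (0.06 log units) apart, within the scatter of two such steps. This rests on two pairs in one assay, and it shows neither why the number falls nor that the step would hold on any other core.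

Going by these compounds, whether bromo or trifluoromethyl at the same place would give a similar step remains open. So does whether a carboxylic acid at the end of the hydroxyl-bearing chain would alter the step.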